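The source may report more compounds than this note shows. Statements on the series, on what has been measured and on what is new or still open speak of the compounds shown alone.

Measured compounds:
- Compound 1, `Cc1ccc(NC(=S)NC(=O)c2cn(-c3ccccc3)nc2-c2ccc(F)cc2)cc1`, gives 2980 nM in a functional assay on NCI-H460 cells (Homo sapiens) for inhibition, read by CCK-8 assay, with a stated time of 48 h; a higher number here means a weaker inhibitor, a lower number a stronger inhibitor.
- Compound 2, `O=C(NC(=S)Nc1ccc(F)cc1)c1cn(-c2ccccc2)nc1-c1ccccc1`, gives 4210 nM in this assay.

Of the compounds shown here, two have been measured in this assay, and compound 2 stands at the higher of the two numbers. Its nearest neighbour is compound 1, whose number is lower, but the gap between them is small enough to sit inside the usual scatter of repeated measurements, so the two cannot be placed in any order.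

The next compound, compound 3, `Cc1ccc(NC(=S)NC(=O)c2cn(-c3ccccc3)nc2-c2ccccc2)cc1`, is made from compound 2 by one change: methyl in place of fluoro on an aromatic carbon. Among the measured compounds shown here, no pair of measured compounds differs in just this way, so there is no measured step to lean on. For the measured compounds named here, with the two known numbers so close together, and no basis for a move in either direction, the step from compound 2 to compound 3 is expected to be small, a 1.2-fold lower number from compound 2 to compound 3 (0.07 log units; within the scatter), no larger than the scatter. Compound 3 is therefore estimated at 3600 nM, somewhere between 1500 nM and 8500 nM in this assay.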

Compound 3, half-maximal inhibitory concentration: 3960 nM
For compound 3 the middle estimate is 1.1-fold (0.04 log units) below the measured one; measured number inside the range.
By their numbers in this assay, from the lowest: compounds 1, 3 and 2 (each within the scatter of the next).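

Read in this assay, methyl in place of fluoro on an aromatic carbon, para to a large group, gives a 1.1-fold lower number from compound 2 to compound 3 (0.03 log units; within the scatter) and so offers the first direct comparison at this position: at this level of precision, the assay does not separate 4-fluorophenyl from 4-methylphenyl here. Compound 3 also links to compound 1 through a second single change, where removing the fluoro gives a 1.3-fold higher number from compound 1 to compound 3 (0.12 log units; within the scatter) and shows that this fluoro can be exchanged for hydrogen with no change that can be read in this assay. No separate measurement is available to explain either result.

The compounds shown leave open whether any group at the first position, such as an amine, a carboxylic acid or a longer chain, would move the number beyond the scatter. They also leave open whether the second position would respond to a group such as methoxy or trifluoromethyl, and whether changes at the two positions would act independently when made together.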